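A few compounds are considered here, and "the series" means these few. Any claim that something is new, unique, unknown or untested is made for them only; others in the source may bear on it.

In a functional assay on K562 cells (Homo sapiens) for antiproliferative activity, read by MTT assay, with a stated time of 24 h (on this read-out higher numbers stand for weaker inhibition and lower numbers for stronger inhibition), compound 1 (`COc1ccc(C(=O)/C=C/c2ccc(N(c3ccccc3)c3ccccc3)cc2)c2c1C=CC(C)(C)O2`) reaches only the limit of the assay, > 10000 nM, so no number is known for it (the limit of > 10000 nM in this assay, at which 1 of the 3 values shown sits). Compound 2 (`COc1ccc(C(=O)/C=C/c2ccc(N3CCCC3)cc2)c2c1C=CC(C)(C)O2`) gives 6180 nM, the highest of the two numbers recorded. Compound 3 (`COc1ccc(C(=O)/C=C/c2ccc3ccccc3n2)c2c1C=CC(C)(C)O2`) gives 3020 nM, a lower number, and the gap between these two lies beyond the scatter. Compound 4 (`COc1ccc(C(=O)/C=C/c2ccc(O)cc2)c2c1C=CC(C)(C)O2`) has not yet been measured; it differs from compound 2 by hydroxy in place of pyrrolidin-1-yl on an aromatic carbon. Within the data shown here, no step between measured compounds bears on this change, so in this assay the step is expected to be small, within the scatter, in either direction. Compound 4 is therefore estimated at 5000 nM, between 1500 nM and 20000 nM, which means a step of a 1.2-fold lower number from compound 2 to compound 4 (0.09 log units; within the scatter).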

Compound 4, half-maximal inhibitory concentration: > 10000 nM
Compound 4: a limit, no number (the forecaster's own chance of this, stated with the estimate: 25%); middle value at least 2.0-fold (0.30 log units) away from the limit.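

In this assay, among these compounds, this is the first step read at this place, on an aromatic carbon para to a large group: hydroxy in place of pyrrolidin-1-yl gives an at least 1.6-fold higher number from compound 2 to compound 4 (0.20 log units; that floor lies within the scatter). From the compounds shown here alone, compound 4 gives > 10000 nM, a limit of the assay and not a number, so only a floor for the step can be read and its true size stays unknown. Compound 4 therefore joins compound 1 at the limit: the limit of > 10000 nM in this assay, at which 2 of the 4 values shown sit.

The compounds shown leave open how a dimethylamino or a methoxy group would read at this place. Such groups could separate the role of the ring from that of the nitrogen.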